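The source may report more compounds than this note shows. Statements on the series, on what has been measured and on what is new or still open speak of the compounds shown alone.

Compound 1 `Nn1c(SCc2ccccc2)nnc1-c1c[nH]c2ccccc12` is the starting point. In a functional assay on Jurkat cells (Homo sapiens) for cytotoxicity, with a stated time of 24 h (a lower number here means a stronger inhibitor, a higher number a weaker inhibitor), compound 1 gives > 100000 nM, which is a limit of the assay rather than a number. Compound 2 `Nn1c(SCc2cccc([N+](=O)[O-])c2)nnc1-c1c[nH]c2ccccc12` carries a nitro group in place of a hydrogen on an aromatic carbon. In this assay compound 2 gives > 100000 nM, again a limit rather than a number. The step that the two limits leave unreadable from compound 1 to compound 2 therefore cannot be read, since both of its ends sit at the limit of > 100000 nM in this assay, at which 2 of the 2 values shown sit.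

Compound 3 `Nn1c(SCc2ccc(Br)cc2)nnc1-c1c[nH]c2ccccc12` has not yet been measured. It differs from compound 1 as follows: bromo in place of hydrogen on an aromatic carbon. Among the compounds with values here, the only measured step alters the same benzyl group, but its size is unreadable, so it gives no guidance on how large a change in this assay to expect from a bromo in place of hydrogen. With both measured values resting at the limit, compound 3 is expected to rest there as well, and the step of a number no higher from compound 1 to compound 3 (the limit leaves the size open) is estimated as nothing that could be seen. For compound 3 the estimate in this assay is 100000 nM, with a range from 30000 nM to 300000 nM.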

Compound 3, half-maximal inhibitory concentration: > 100000 nM
Compound 3: a limit, no number; the forecaster's own chance of this, stated with the estimate: 85%; the middle value lies on the limit itself.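

In this assay compound 3 gives > 100000 nM as a limit of the assay, not a number. The step from compound 1 to compound 3 therefore cannot be read, as with every value so far: the limit of > 100000 nM in this assay, at which 3 of the 3 values shown sit.

The compounds shown leave open how strongly compound 1, compound 2 and compound 3 act on these cells, and whether the nitro or bromo group changes that at all.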